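This account rests on a few compounds, and the source may have more. Where it says the series, first, only, none or still open, it means among the compounds named here.

Working notes on the series.

Three compounds of a shared core have numbers in a functional assay on MCF7 cells (Homo sapiens) for inhibition, read by sulforhodamine B assay, with a stated time of 48 h; on this read-out lower numbers stand for stronger inhibition of growth and higher numbers for weaker inhibition of growth. Compound 1 `COc1ccc2c(c1)NC(=O)CN2c1nc(Nc2ccc(C#N)cc2)nc2ccccc12` gives 9.19 nM and stands second highest of the three. Compound 2 `COc1ccc2c(c1)NC(=O)CN2c1nc(NC2CC2)nc2ccccc12` gives 1.08 nM, the step being an 8.5-fold lower number from compound 1 to compound 2 (0.93 log units; beyond the scatter). Compound 3 `COc1ccc2c(c1)NC(=O)CN2c1nc(COC(C)=O)nc2ccccc12` gives 33 nM, the step being a 3.6-fold higher number from compound 1 to compound 3 (0.56 log units; beyond the scatter); from compound 2 the change is a 31-fold higher number from compound 2 to compound 3 (1.49 log units; beyond the scatter).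

Compound 4 `COc1ccc2c(c1)NC(=O)CN2c1nc(N2CC(OC)C2)nc2ccccc12` is not yet measured. It differs from compound 1 by 3-methoxyazetidin-1-yl in place of (4-cyanophenyl)amino on an aromatic carbon. Both measured steps from compound 1 bear on this change in that they replace the same group on the same aromatic carbon, the one between two ring nitrogen atoms; one step is modest and downward, the other modest and upward. A small saturated ring in place of the (4-cyanophenyl)amino group resembles the change to compound 2 more than that to compound 3, so a small step downward in this assay is expected, and it may stay within the scatter. For compound 4 the expected value is 5 nM, range 1.2 nM to 20 nM. The expected step is a 1.8-fold lower number from compound 1 to compound 4 (0.26 log units; within the scatter).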

Compound 4, concentration for 50% growth inhibition: 8.6 nM
Compound 4: middle estimate off by 1.7-fold (0.24 log units), on the low side; measured number inside the range.
By their numbers in this assay, from the lowest: compound 2; then compounds 4 and 1 (each within the scatter of the next); then compound 3.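

In this assay, the aromatic carbon between two ring nitrogen atoms accepts 3-methoxyazetidin-1-yl in place of (4-cyanophenyl)amino with no readable change (a 1.1-fold lower number from compound 1 to compound 4 (0.03 log units; within the scatter)), so here a four-membered non-aromatic ring and a six-membered aromatic ring of carbon cannot be told apart. A small saturated ring at this carbon does not by itself give the low number of compound 2 (an 8.0-fold higher number from compound 2 to compound 4 (0.90 log units; beyond the scatter)), although 3-methoxyazetidin-1-yl still stands apart from acetoxymethyl (a 3.8-fold lower number from compound 3 to compound 4 (0.58 log units; beyond the scatter)). No measurement available here accounts for these differences.

Open, going by these compounds, is whether azetidin-1-yl without the methoxy group, or a larger saturated ring such as morpholin-4-yl, would stay with compound 4 or move toward compound 2. Also open, on these data alone, is whether a longer chain on the amino nitrogen, such as propylamino, would match cyclopropylamino.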